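Cyclohexyl to phenyl swap across two piperidine-derived sulfonamide cores

A few compounds are considered here, and "the series" means these few. Any claim that something is new, unique, unknown or untested is made for them only; others in the source may bear on it.

Measured so far:
Compound 1 `Cc1ccc(S(=O)(=O)N2CC[C@@H](Br)C[C@@H]2C2CCCCC2)cc1`: 14000 nM
Compound 2 `Cc1ccc(S(=O)(=O)N2CC[C@@H](Br)C[C@@H]2c2ccccc2)cc1`: 36000 nM
Compound 3 `Cc1ccc(S(=O)(=O)N2CCC(Cl)=CC2C2CCCCC2)cc1`: 24000 nM

All values come from a functional assay on WiDr cells (Homo sapiens) for antiproliferative activity, read by sulforhodamine B assay, with a stated time of 48 h; on this read-out higher numbers stand for weaker inhibition of growth and lower numbers for stronger inhibition of growth. Compound 4 `Cc1ccc(S(=O)(=O)N2CCC(Cl)=CC2c2ccccc2)cc1` has not yet been measured there.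

Compound 1 and compound 2 differ by one change, (phenyl in place of cyclohexyl on a saturated ring carbon), and the step is a 2.6-fold higher number from compound 1 to compound 2 (0.41 log units; beyond the scatter). Compound 3 and compound 4 differ by phenyl in place of cyclohexyl on a saturated ring carbon. Among the measured compounds shown here, the change is the same kind of change as the one from compound 1 to compound 2, but the surroundings are not identical: in compound 1 the saturated ring carbon lies two ring bonds from the ring atom that bears a bromo group, in compound 3 two ring bonds from the ring atom that bears a chloro group. The difference between the core of compound 1 and the core of compound 3 is not broken down here; what can be said is that compound 3, in this assay, gives 24000 nM, within the scatter of both compound 1 and compound 2.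

For the measured compounds named here, with only one measured step of this kind, the expectation for compound 4 rests on that one pair. For compound 4 a step of about a 2.4-fold higher number from compound 3 to compound 4 (0.38 log units; beyond the scatter) is expected, since the change on the core of compound 1 gave a 2.6-fold higher number from compound 1 to compound 2 (0.41 log units; beyond the scatter). Compound 4 is accordingly estimated at 58000 nM, with a range of 25000 nM to 135000 nM; a weak number this high may also be reported as a limit in this assay.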

Compound 4, concentration for 50% growth inhibition: 18000 nM
For compound 4 the middle estimate is 3.2-fold (0.51 log units) above the measured one; measured number below the stated range.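

In this assay, the swap of cyclohexyl for phenyl does not carry over unchanged from one core to the other: the same change on two cores in this assay, a 2.6-fold higher number (0.41 log units; beyond the scatter) from compound 1 to compound 2 and a 1.3-fold lower number (0.12 log units; within the scatter) from compound 3 to compound 4, 3.4-fold (0.54 log units) apart, beyond the scatter of two such steps. On the core of compound 3 the swap gives a 1.3-fold lower number from compound 3 to compound 4 (0.12 log units; within the scatter), so phenyl and cyclohexyl cannot be told apart on this core in this read-out, and the step seen on the core of compound 1 is no guide here. The two pairs do not show which difference between the cores goes with this gap, and a single pair on each core supports no general rule for the series.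

Open, from the compounds shown here alone, is how this assay responds at this saturated ring carbon to a group other than cyclohexyl or phenyl, such as a carboxylic acid, an amine or a longer chain. Also open, going by these compounds, is whether the step seen on the core of compound 3 holds with a methoxy group or a fluoro group in place of the chloro group.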